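Swapping a methoxy for hydrogen in compound 2

The compounds below may be only part of what the source reports. "The series", "measured", "known", "first", "only" and "open" are said of these compounds alone.

In a functional assay on a cell-free system (Platelet, plasma, Oryctolagus cuniculus) for inhibition, with a stated time of 5 min, at 37 degrees C (on this read-out lower numbers stand for stronger inhibition and higher numbers for weaker inhibition), compound 1 (`COc1cc(/C=C/C(=O)O)ccc1OC(=O)c1nc(C)c(C)nc1C`) reads 44600 nM and compound 2 (`CCOC(=O)/C=C/c1cc(OC)c(OC(=O)c2nc(C)c(C)nc2C)c(OC)c1`) reads 37500 nM on the same scale. These two values lie within the usual scatter of each other, so compound 2 stands level with compound 1. Compound 3 (`CCOC(=O)/C=C/c1ccc(OC(=O)c2nc(C)c(C)nc2C)c(OC)c1`) differs from compound 2 at one place, with hydrogen in place of methoxy on an aromatic carbon. Going by the values given here, no measured pair shows this change alone, and a step in this assay no larger than the scatter, without a clear direction, is expected. The value expected for compound 3 is 40000 nM within an estimated range of 15000 nM to 100000 nM in this read-out. The estimate amounts to a 1.1-fold higher number from compound 2 to compound 3 (0.03 log units; within the scatter) as the expected step.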

Compound 3, half-maximal inhibitory concentration: 58400 nM
Beside the measured number, compound 3's estimate is 1.5-fold (0.16 log units) below it, and the stated range covers the measured number.
By their numbers in this assay, from the lowest: compounds 2, 1 and 3 (each within the scatter of the next).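

In this assay, hydrogen in place of methoxy on an aromatic carbon gives a 1.6-fold higher number from compound 2 to compound 3 (0.19 log units; within the scatter) and stays within the scatter, so at this position, ortho to a large group, the methoxy shows no clear effect on the read-out. Ethyl in place of hydrogen on an oxygen next to a carbonyl group gives a 1.3-fold higher number from compound 1 to compound 3 (0.12 log units; within the scatter) and also stays within the scatter, so the ethyl ester and the carboxylic acid read level. Nothing at hand explains these small steps. The compounds shown leave open whether a hydroxyl, an amine or a longer alkoxy chain at this position would read differently.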